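Aryl Substituent Swap on the Shared Core

This account rests on a few compounds, and the source may have more. Where it says the series, first, only, none or still open, it means among the compounds named here.

Going by the values given here, compound 2 `C=CC(=O)Nc1cccc(NC(=O)CSc2nc(Nc3cccc(C)c3)c3ccccc3n2)c1` gives 16800 nM in a functional assay on MDA-MB-231 cells (Homo sapiens) for inhibition, read by MTT assay, with a stated time of 72 h (on this read-out lower numbers stand for stronger inhibition and higher numbers for weaker inhibition), the only value shown there as a number. Compound 1 `C=CC(=O)Nc1cccc(NC(=O)CSc2nc(Nc3cccc([N+](=O)[O-])c3)c3ccccc3n2)c1` is reported in this assay only as a limit, > 50000 nM. Among the compounds with values here, the sole measured change, an at least 2.9-fold lower number from compound 1 to compound 2 (0.47 log units; beyond the scatter), rests on the limit of > 50000 nM in this assay, at which 1 of the 2 values shown sits, and alters the substituent on this same aryl group. Compound 3 `C=CC(=O)Nc1cccc(NC(=O)CSc2nc(Nc3ccc(Br)cc3)c3ccccc3n2)c1` differs from compound 2 by 4-bromophenyl in place of 3-methylphenyl on a nitrogen on an aromatic ring. That measured step concerns a different substituent, and sets no firm direction here; a step of a 1.5-fold higher number from compound 2 to compound 3 (0.17 log units; within the scatter) is expected, a modest weakening at most. Compound 3 is therefore estimated at 25000 nM, between 8000 nM and 80000 nM.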

Compound 3, half-maximal inhibitory concentration: 17300 nM
Compound 3: the middle estimate sits 1.4-fold (0.16 log units) above what was measured; measured number inside the range.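

In this assay, 4-bromophenyl in place of 3-methylphenyl on the nitrogen leaves the read-out within the scatter, a 1.0-fold higher number from compound 2 to compound 3 (0.01 log units; within the scatter), so this position accepts both aryl groups without a change that can be read. Against the 3-nitrophenyl group, the step is beyond the scatter, an at least 2.8-fold lower number from compound 1 to compound 3 (0.46 log units; beyond the scatter), which now holds for two different aryl groups. This comparison rests on a limit rather than a number: the limit of > 50000 nM in this assay, at which 1 of the 3 values shown sits.

The compounds shown leave open whether the substituent or its place on the ring matters, as 3-methylphenyl and 4-bromophenyl differ in both. On these data alone, how 3-bromophenyl, 4-methylphenyl or an aminophenyl group would read here also stays open.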